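The compounds below may be only part of what the source reports. "The series", "measured", "known", "first", "only" and "open" are said of these compounds alone.

Measured compounds in a functional assay on BJAB cells (Homo sapiens) for antiproliferative activity, with a stated time of 4 days; on this read-out lower numbers stand for an effect already at smaller amounts and higher numbers for an effect only at larger amounts of compound:
- compound 1 `Cc1cc(C)cc(-c2c(C)nn(-c3nc(-c4ccc(Cl)c(Cl)c4)c(SC(C)C)s3)c2C(=O)O)c1`: 2700 nM
- compound 2 `COc1cc(Cl)cc(-c2c(C)nn(-c3nc(-c4ccc(Cl)c(Cl)c4)c(SC(C)C)s3)c2C(=O)O)c1`: 760 nM
- compound 3 `Cc1nn(-c2nc(-c3ccc(Cl)c(Cl)c3)c(SC(C)C)s2)c(C(=O)O)c1-c1ccc(C(F)(F)F)cc1`: 3500 nM

Compound 3 carries the highest of the three numbers, though its number and that of compound 1 lie within the scatter of each other; against compound 2 it shows a 4.6-fold higher number from compound 2 to compound 3 (0.66 log units; beyond the scatter). Compound 4 `CCOc1ncccc1-c1c(C)nn(-c2nc(-c3ccc(Cl)c(Cl)c3)c(SC(C)C)s2)c1C(=O)O` differs from compound 3 in one place: 2-ethoxypyridin-3-yl in place of 4-(trifluoromethyl)phenyl on an aromatic carbon.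

Within the data shown here, two measured steps bear on this position. The change from compound 1 to compound 3 gave a 1.3-fold higher number from compound 1 to compound 3 (0.11 log units; within the scatter), while the change from compound 1 to compound 2 gave a 3.6-fold lower number from compound 1 to compound 2 (0.55 log units; beyond the scatter). Exchanging the aryl group at this position has therefore moved the number at most modestly. Among the measured compounds shown here, compound 2, the only one with an oxygen-bearing ring here, gave the lowest number, and compound 4 likewise brings an oxygen and a ring nitrogen. For the measured compounds named here, a modest move toward lower numbers is therefore expected, a 2.3-fold lower number from compound 3 to compound 4 (0.37 log units; beyond the scatter), though the single relevant pair is thin evidence. Compound 4 is estimated at 1500 nM, between 500 nM and 5000 nM.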

Compound 4, half-maximal effective concentration: 11000 nM
Compound 4: middle estimate off by 7.3-fold (0.87 log units), on the low side; the measured number lies above the stated range.
By their numbers in this assay, from the lowest: compound 2; then compounds 1 and 3 (each within the scatter of the next); then compound 4.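

In this assay, compound 4 has the highest number of the four, with a 3.1-fold higher number from compound 3 to compound 4 (0.50 log units; beyond the scatter) and a 4.1-fold higher number from compound 1 to compound 4 (0.61 log units; beyond the scatter), so this position can also move the number upward from the level shared by compound 1 and compound 3. The largest step at this position is now a 14-fold higher number from compound 2 to compound 4 (1.16 log units; beyond the scatter), and it joins two compounds that both carry an oxygen on this ring, so an oxygen-bearing group does not by itself go with a lower number. Nothing measured on these compounds gives a reason for this rise.

From the compounds shown here alone, it remains open whether the higher number goes with the ring nitrogen, the ethoxy chain or the two together. A plain pyridin-3-yl group and a 2-ethoxyphenyl group, each holding only one of the two features, would separate them.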